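The compounds below may be only part of what the source reports. "The series", "measured", "known", "first", "only" and "open" are said of these compounds alone.

Compound 1 `Cc1cc(C(N)=O)nn1Cc1cc(Cl)ccc1OCC(C)C` gives in a physicochemical assay for lipophilicity, at pH 7.4 (a higher number here means a more lipophilic compound, a lower number a more polar compound), a value of 3.1. Compound 2 `Cc1cc(C(=O)NN2CCCCC2)nn1Cc1cc(Cl)ccc1OCC(C)C` shows 3.3 in this assay, and the step of a number 0.20 log units higher from compound 1 to compound 2 (within the scatter) is the only measured one. Compound 3 `CC(=O)Nc1cc(C)n(Cc2cc(Cl)ccc2OCc2ccccc2)n1` reaches in this assay only a limit of the assay, > 3.7, so where it truly stands above that mark is not known. The mark is the limit of > 3.7 in this assay, at which 1 of the 3 values shown sits.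

Compound 4 `Cc1cc(NC(=O)OCc2ccccc2)nn1Cc1cc(Cl)ccc1OCc1ccccc1` differs from compound 3 by benzyloxy in place of methyl on a carbonyl carbon. Within the data shown here, no measured step covers this kind of change; the step from compound 1 to compound 2 concerns a different position and group. Compound 4 is therefore expected to stay at or beyond the limit, estimated at 4.8 with a range of 4 to 5.6, which would mean an expected step that the limit leaves unreadable from compound 3 to compound 4.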

Compound 4, distribution coefficient: 3.1
For compound 4 the middle estimate is 1.70 log units above the measured one; measured number outside the range, below it.
By their numbers in this assay, from the lowest: compounds 1, 4 and 2 (each within the scatter of the next). At a limit, above all of these: compound 3.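

In this assay, benzyloxy in place of methyl on a carbonyl carbon whose other neighbour is an amide-type nitrogen gives a number at least 0.60 log units lower from compound 3 to compound 4 (beyond the scatter), even though benzyloxy has 8 heavy atoms where methyl has 1. Among these compounds, the only earlier step, a number 0.20 log units higher from compound 1 to compound 2 (within the scatter), concerned a different position and group. Compound 3 stands at a limit, so the full size of the new step cannot be read: the limit of > 3.7 in this assay, at which 1 of the 4 values shown sits.

Which part of benzyloxy goes with the lower number stays open. Ethoxy, phenyl or a dimethylamino group on this carbonyl carbon could separate the oxygen from the ring.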